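Oxazol-2-yl in Place of the Pyrazole on a Fused Core

The source may hold more compounds than are shown below. What is called first, only, known or untested is meant among the compounds shown, and "the series" means these compounds.

Within the data shown here, in a functional assay on CHO cells for agonist activity at Alpha-1A adrenergic receptor (Homo sapiens), read by FLIPR and calcium flux (on this read-out lower numbers stand for an effect already at smaller amounts and higher numbers for an effect only at larger amounts of compound), compound 2 `Cc1n[nH]cc1-c1cccc2c1CCC2c1ncc[nH]1` gives 3 nM, the lowest of the two numbers known, while compound 1 `Cc1oncc1-c1cccc2c1CCC2c1ncc[nH]1` gives 111 nM. Compound 3 `c1cc(-c2ncco2)c2c(c1)C(c1ncc[nH]1)CC2` is not yet measured. The change is 1,3-oxazol-2-yl in place of 3-methyl-1H-pyrazol-4-yl on an aromatic carbon. Among the measured compounds shown here, the only step known, a 37-fold lower number from compound 1 to compound 2 (1.57 log units; beyond the scatter), came with the arrival of the same 3-methyl-1H-pyrazol-4-yl that now leaves, in place of a ring without a donor. A large step back toward higher numbers is therefore expected, a 27-fold higher number from compound 2 to compound 3 (1.43 log units; beyond the scatter). For compound 3 the estimate in this assay is 80 nM, in a range from 15 nM to 400 nM.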

Compound 3, half-maximal effective concentration: 170 nM
For compound 3 the middle estimate is 2.1-fold (0.33 log units) below the measured one, within the range that was stated.
By their numbers in this assay, from the lowest: compound 2; then compounds 1 and 3 (each within the scatter of the next).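

In this assay, 1,3-oxazol-2-yl in place of 3-methyl-1H-pyrazol-4-yl on this aromatic carbon gives a 57-fold higher number from compound 2 to compound 3 (1.75 log units; beyond the scatter), which takes away the low number that the pyrazole had brought. Between the two rings without a hydrogen-bond donor there is a 1.5-fold higher number from compound 1 to compound 3 (0.19 log units; within the scatter), so among these three compounds only the pyrazole of compound 2 stands apart. Nothing available explains this difference. Going by these compounds, it remains open whether a pyrazole carrying methyl on its ring nitrogen would keep the low number, and what an unsubstituted pyrazole or an amide would give on this carbon.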